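Three Trimethoxyphenyl Naphthyl Carbinols and an Untested Cinnamyl Analogue

This account rests on a few compounds, and the source may have more. Where it says the series, first, only, none or still open, it means among the compounds named here.

The series shares a core in which a trimethoxyphenyl ring and a naphthyl ring sit on one saturated carbon, and it was examined in a functional assay on THP-1 cells (Homo sapiens) for inhibition, read by sulforhodamine B assay, with a stated time of 48 h; on this read-out higher numbers stand for weaker inhibition and lower numbers for stronger inhibition. Compound 1, `CCOC(=O)C(C)C(O)(c1ccc(OC)c(OC)c1OC)c1cccc2ccccc12`, gives a value that is a limit of the assay, > 20000 nM, rather than a number. Compound 2, `COc1ccc(C(c2ccccc2O)c2cccc3ccccc23)c(OC)c1OC`, likewise gives only a limit, > 20000 nM. Compound 3, `COc1cc(COC(c2ccc(OC)c(OC)c2OC)c2cccc3ccccc23)cc(OC)c1`, gives a limit as well, > 20000 nM. Because of the limit of > 20000 nM in this assay, at which 3 of the 3 values shown sit, compound 1 cannot be ranked against the other two: all three results sit at the same limit, and nothing separates them. No comparison between two measured compounds is therefore available to guide expectations for a new analogue.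

Compound 4, `COc1ccc(C(O)(C/C=C\c2ccccc2)c2cccc3ccccc23)c(OC)c1OC`, is not yet measured in this assay . It differs from compound 1 in one place: 3-phenylprop-2-en-1-yl in place of 1-(ethoxycarbonyl)ethyl on a saturated chain carbon bound to two aromatic carbons and an oxygen on a saturated carbon. Among the measured compounds shown here, with no measured step to lean on, the account can only note that every compound known so far stops at the limit. Compound 4 is expected to give 15000 nM, with a range from 3000 nM to 60000 nM. The step from compound 1 to compound 4 is estimated at an at least 1.3-fold lower number from compound 1 to compound 4 (0.12 log units; that floor lies within the scatter), which is expected to remain within the scatter of the assay.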

Compound 4, half-maximal inhibitory concentration: 19400 nM
Beside the measured number, compound 4's estimate is 1.3-fold (0.11 log units) below it, within the range that was stated.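

In this assay, compound 4 is the only compound shown that gives a number rather than a limit, so the position on a saturated chain carbon bound to two aromatic carbons and an oxygen on a saturated carbon now has a readable result. Putting 3-phenylprop-2-en-1-yl in place of 1-(ethoxycarbonyl)ethyl there exchanges a group with two hydrogen-bond acceptors for one with none and a six-membered aromatic ring of carbon only, and the change gives an at least 1.0-fold lower number from compound 1 to compound 4 (0.01 log units; that floor lies within the scatter). This step is only a floor, and its true size cannot be read, because one end of it is a limit: the limit of > 20000 nM in this assay, at which 3 of the 4 values shown sit.

On these data alone, whether an amine or a carboxylic acid at this position, or a longer chain ending in a phenyl ring, would give a clearly lower number remains open. The compounds shown also leave open whether the double bond in 3-phenylprop-2-en-1-yl contributes to the result, and any steps involving compound 2 and compound 3 cannot be read.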